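The source may report more compounds than this note shows. Statements on the series, on what has been measured and on what is new or still open speak of the compounds shown alone.

For the measured compounds named here, in a functional assay on A549 cells (Homo sapiens) for antiproliferative activity, read by MTT assay, with a stated time of 48 h (on this read-out higher numbers stand for weaker inhibition and lower numbers for stronger inhibition), compound 1 `COc1ccc(/C=C/c2cc(OC)cc(OC)c2/C=C/C(=O)c2cccc(OC)c2)cc1` gives 6.1 ug/mL and compound 2 `COc1ccc(/C=C/c2cc(OC)cc(OC)c2/C=C/C(=O)c2ccccc2C)cc1` gives 5.9 ug/mL, so compound 2 stands level with compound 1, the only other measured compound. Compound 3 `COc1ccc(/C=C/c2cc(OC)cc(OC)c2/C=C/C(=O)c2ccc(OC)cc2)cc1` carries 4-methoxyphenyl in place of 2-methylphenyl on a carbonyl carbon. Going by the values given here, the one measured step that bears on this change, a 1.0-fold lower number from compound 1 to compound 2 (0.01 log units; within the scatter), exchanged the group on the same carbonyl carbon and stayed within the scatter. No shift beyond the scatter is therefore expected in this assay, and the estimated step is a 1.0-fold higher number from compound 2 to compound 3 (0.01 log units; within the scatter). Compound 3 is expected at 6 ug/mL, in a range from 3 ug/mL to 12 ug/mL.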

Compound 3, half-maximal inhibitory concentration: 4.5 ug/mL
The estimate for compound 3 lay 1.3-fold (0.12 log units) above the measured number; low and high end bracket the measured number.
By their numbers in this assay, from the lowest: compounds 3, 2 and 1 (each within the scatter of the next).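

In this assay the step of a 1.3-fold lower number from compound 2 to compound 3 (0.12 log units; within the scatter) and the step of a 1.4-fold lower number from compound 1 to compound 3 (0.13 log units; within the scatter) both leave the number level with the earlier ones. Three different aryl groups on this carbonyl carbon now stand together, and the exchange of 3-methoxyphenyl for 4-methoxyphenyl, a change of methoxy placement alone, also produces no shift beyond the scatter. No measurement is available that would account for this flat reading. Still open, going by these compounds, is whether a group other than a substituted phenyl, such as an amine or a carboxylic acid, would shift the number on this carbonyl carbon.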